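The source may report more compounds than this note shows. Statements on the series, on what has been measured and on what is new or still open speak of the compounds shown alone.

Compound 1 `Clc1ccc(CO/N=C/c2c(-c3ccc(C4CCCCC4)cc3)nc3sccn23)cc1Cl`: in an assay on HepG2 cells for agonist activity at nuclear receptor subfamily 1 group I member 3 (Homo sapiens), read by a luciferase reporter, with a stated time of 23 h (on this read-out lower numbers stand for an effect already at smaller amounts and higher numbers for an effect only at larger amounts of compound), compound 1 reaches only the assay limit > 100000 nM, which is a boundary of the measurement and not a number.
Compound 2 `Clc1ccc(CO/N=C/c2c(-c3ccc4ccccc4c3)nc3occn23)cc1Cl`: in this assay compound 2 gives 370 nM.
Compound 3 `C(=N/OCc1ccc(Oc2ccccc2)cc1)\c1c(-c2ccc3ccccc3c2)nc2occn12`: in this assay compound 3 is reported as "not active" (no number reported).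

Among the three values shown, compound 1 stands at the weak end: its entry in this assay is a limit (the limit of > 100000 nM in this assay, at which 1 of the 3 values shown sits), so all that is known is that no effect appeared up to the highest amount tested. Compound 2 is the only one of the three with a real number, and compound 3 has no number at all. Compound 2 and compound 3 share one core and differ from compound 1 in both the core and the aromatic substituent, so no single change can be read off between any pair of measured compounds.

Compound 4 `Clc1ccc(CO/N=C/c2c(-c3ccccc3)nc3sccn23)cc1Cl` differs from compound 1 in one place: hydrogen in place of cyclohexyl on an aromatic carbon. Going by the values given here, with no measured step of this kind to lean on, and with compound 1 sitting at the limit in this assay, the step to compound 4 is expected to be small, in neither direction beyond the usual scatter. The expected step of a number no higher from compound 1 to compound 4 (the limit leaves the size open) is estimated to stay within that scatter. Compound 4 is therefore expected to give about 100000 nM, within a range from 20000 nM to 300000 nM, and most likely only a limit again.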

Compound 4, half-maximal effective concentration: 580 nM
Compound 4: middle estimate off by 170-fold (2.24 log units), on the high side; the whole stated range lies above it.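

In this assay, going by these compounds alone, hydrogen in place of cyclohexyl on this aromatic carbon is the first single change that can be read, and it gives an at least 170-fold lower number from compound 1 to compound 4 (2.23 log units; beyond the scatter). The group at this place, para to a large group, can therefore decide whether this core gives a measurable number at all: with cyclohexyl there is none, and with hydrogen there is one. The printed step is only a minimum, as the entry of compound 1 is a limit: the limit of > 100000 nM in this assay, at which 1 of the 4 values shown sits.

With only hydrogen and cyclohexyl shown at this carbon, it remains open where along a series of groups the number would be lost, and a methyl, a methoxy or a short propyl chain could fall on either side. Going by these compounds, it also remains open whether an amine or a carboxylic acid at this place would behave like hydrogen or like cyclohexyl, and whether the same change would matter as much on the core of compound 2.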